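Benzyl variation on a shared pyridinone-indazole inhibitor series

A few compounds are considered here, and "the series" means these few. Any claim that something is new, unique, unknown or untested is made for them only; others in the source may bear on it.

Measured so far:
compound 1, `O=c1ccc(-c2ccc3cn[nH]c3c2)cn1Cc1ccccc1C(F)(F)F`, 100 nM
compound 2, `O=c1ccc(-c2ccc3cn[nH]c3c2)cn1Cc1ccc(Cl)c(Cl)c1`, 97 nM
compound 3, `O=c1ccc(-c2ccc3cn[nH]c3c2)cn1Cc1cccc(F)c1`, 38 nM

In an assay for inhibition of MAP kinase-interacting serine/threonine-protein kinase 2 (Homo sapiens), read by luminescence and ADP-Glo, with a stated time of 2 h (a lower number here means a stronger inhibitor, a higher number a weaker inhibitor), compound 3 gives the lowest number of the three, and both steps to it are beyond the scatter: from compound 2 the change is a 2.6-fold lower number from compound 2 to compound 3 (0.41 log units; beyond the scatter), and compound 1 stands at 100 nM against compound 3 at 38 nM, a comparable gap, so compound 3 is the most potent of the set.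

Compound 4, `O=c1ccc(-c2ccc3cn[nH]c3c2)cn1Cc1ccccc1Cl`, is next: 2-chlorophenyl in place of 3-fluorophenyl on a saturated chain carbon bound to an aromatic nitrogen

For the measured compounds named here, one measured step bears on this. Replacing 3,4-dichlorophenyl with 3-fluorophenyl gave a 2.6-fold lower number from compound 2 to compound 3 (0.41 log units; beyond the scatter), and the only other substituted benzyl variant, compound 1, sits close to compound 2. Going by the values given here, both variants that carry a substituent other than the single fluorine of compound 3 therefore land at a higher number. Among the compounds with values here, no measured pair isolates a chlorine on the 2-position, so the direction for compound 4 rests on these two comparisons alone, and a modest move back toward the numbers of compounds 1 and 2 is expected.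

For compound 4 in this assay the estimate is 75 nM, between 35 nM and 160 nM.

This implies an expected step of a 2.0-fold higher number from compound 3 to compound 4 (0.30 log units; within the scatter), a rise of modest size, possibly within the scatter.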

Compound 4, half-maximal inhibitory concentration: 78 nM
For compound 4 the middle estimate is 1.0-fold (0.02 log units) below the measured one; measured number inside the range.
By their numbers in this assay, from the lowest: compound 3; then compounds 4, 2 and 1 (each within the scatter of the next).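

In this assay the change to 2-chlorophenyl gives a 2.1-fold higher number from compound 3 to compound 4 (0.31 log units; beyond the scatter), which leaves compound 3 with the lowest number, its steps to compounds 1, 2 and 4 all being beyond the scatter. Compound 4 does not separate from the other two: chloro in place of trifluoromethyl on an aromatic carbon gives a 1.3-fold lower number from compound 1 to compound 4 (0.11 log units; within the scatter), and 2-chlorophenyl in place of 3,4-dichlorophenyl gives a 1.2-fold lower number from compound 2 to compound 4 (0.09 log units; within the scatter), so three differently substituted benzyl groups cannot be told apart here and only the 3-fluorobenzyl group of compound 3 stands off from them. Nothing measured alongside these numbers accounts for that gap.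

Going by these compounds, whether the lower number of compound 3 goes with the fluorine or with its place on the ring stays open, since a pair such as 3-chlorophenyl against 3-fluorophenyl, or 2-fluorophenyl against 2-chlorophenyl, would be needed to separate the two. Also open, on these data alone, is how the series responds to a benzyl group carrying an amine or a carboxylic acid, or to a longer chain in place of the benzyl group.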